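From Cyclohexyloxycarbonyl to Isopropylsulfonyl on an Amine Nitrogen

The compounds below may be only part of what the source reports. "The series", "measured", "known", "first", "only" and "open" are said of these compounds alone.

Compound 1 (`COc1ccc(-c2c(C)nc3c(N4CC[C@@H](NC(=O)NC(C)C)C4)cc(C)nn23)cc1OC`) and compound 2 (`COc1ccc(-c2c(C)nc3c(N4CC[C@@H](NC(=O)OC5CCCCC5)C4)cc(C)nn23)cc1OC`) share a core and differ in one place. In an ADME assay on microsomes from liver (Homo sapiens) for metabolic stability, read by LC-MS, with NADPH named in the record, with a stated time of 60 min, tested at 1 uM, in the absence of a further agent (a lower number here means that less of the compound is left, a higher number that more of the compound is left), compound 1 gives > 95% as a limit of the assay, not a number. Within the data shown here, compound 2 gives > 95% as a limit too, so its standing can be told only as a limit, and the one further value shown is also a limit.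

Compound 3 (`COc1ccc(-c2c(C)nc3c(N4CC[C@@H](NS(=O)(=O)C(C)C)C4)cc(C)nn23)cc1OC`) has not yet been measured. It carries isopropylsulfonyl in place of cyclohexyloxycarbonyl on an amine nitrogen. Among the measured compounds shown here, the one measured step that bears on this is a step that the two limits leave unreadable from compound 1 to compound 2 and it offers no size to carry over. For the measured compounds named here, both measured compounds sit at the limit of > 95% in this assay, at which 2 of the 2 values shown sit, and that is the only guide available.

Compound 2 remains the starting point at > 95% as a limit, so no step beyond the usual scatter is expected in this assay in either direction. The estimated a number at least 1 percentage points lower from compound 2 to compound 3 (that floor lies within the scatter) is accordingly small. Compound 3 is expected at 94% with an estimated range from 80% to 100% in this measurement.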

Compound 3, percent of the compound remaining: > 95%
Compound 3 was reported as a limit; the forecaster's own chance of this, stated with the estimate: 55%; middle value at least 1 percentage points away from the limit.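

In this assay compound 3 gives > 95% as a limit of the assay, not a number. No step among compound 1, compound 2 and compound 3 can be read, because all three stand at the same limit: the limit of > 95% in this assay, at which 3 of the 3 values shown sit.

The compounds shown leave open how far these three differ in the percent of compound remaining, if they differ at all.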